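Trifluoromethyl on the phenyl ring of the thiophene acrylamide

The source may hold more compounds than are shown below. What is called first, only, known or untested is meant among the compounds shown, and "the series" means these compounds.

Measured compounds:
- compound 1 `C/C(=C\c1ccc(-c2ccc(F)cc2)o1)C(N)=O`: 2030 nM
- compound 2 `C/C(=C\c1cc(-c2ccccc2)cs1)C(N)=O`: 12700 nM
- compound 3 `C/C(=C\c1cc(-c2ccccc2C)cs1)C(N)=O`: 19400 nM

In a functional assay on HeLa cells (Homo sapiens) for cytotoxicity, read by CCK-8 assay, with a stated time of 24 h (on this read-out lower numbers stand for stronger inhibition and higher numbers for weaker inhibition), compound 2 gives 12700 nM, the second highest of the three numbers. Its nearest neighbour is compound 3 with 19400 nM; the step of a 1.5-fold higher number from compound 2 to compound 3 (0.18 log units; within the scatter) lies within the scatter. Going by the values given here, compound 1, built on a different core, gives 2030 nM, a lower number than compound 2, but no step between these two is worked out here.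

Compound 4 `C/C(=C\c1cc(-c2ccc(C(F)(F)F)cc2)cs1)C(N)=O` differs from compound 2 by trifluoromethyl in place of hydrogen on an aromatic carbon, on an aromatic carbon of a six-membered aromatic ring of carbon only. Among the compounds with values here, the only measured step that bears on it is the one from compound 2 to compound 3, a substituent on the same ring, which stayed within the scatter. Nothing in the data shows that a group on this ring moves this read-out beyond the scatter. Compound 4 is therefore expected near the value of compound 2, with a 1.1-fold lower number from compound 2 to compound 4 (0.02 log units; within the scatter) estimated as no change beyond the scatter. The estimate for compound 4 in this assay is 12000 nM, in the range 5000 nM to 30000 nM.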

Compound 4, half-maximal inhibitory concentration: > 50000 nM
Compound 4 ended at the assay's limit; the forecaster's own chance of this, stated with the estimate: 10%; at least 4.1-fold (0.61 log units) between middle value and limit.
By their numbers in this assay, from the lowest: compound 1; then compounds 2 and 3 (each within the scatter of the next). At a limit, above all of these: compound 4.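

In this assay compound 4 gives > 50000 nM, which is a limit of the assay and not a number: the limit of > 50000 nM in this assay, at which 1 of the 4 values shown sits.

Trifluoromethyl in place of hydrogen, para to a large group, still gives a readable result, an at least 3.9-fold higher number from compound 2 to compound 4 (0.59 log units; beyond the scatter), whereas methyl in place of hydrogen on the same ring gave a 1.5-fold higher number from compound 2 to compound 3 (0.18 log units; within the scatter). This six-membered aromatic ring is therefore not indifferent to substitution: a group placed on it can shift the number beyond the scatter, towards weaker inhibition, though the full size of this step stays hidden behind the limit.

Open, going by these compounds, is how an amine or a carboxylic acid para to the large group would read. Also open, on these data alone, is whether trifluoromethyl on the phenyl ring of compound 1's core would shift its number in the same way.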